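From 2-fluorobenzyl to 4-bromobenzyl on a shared core

This account rests on a few compounds, and the source may have more. Where it says the series, first, only, none or still open, it means among the compounds named here.

Among the measured compounds shown here, in a functional assay on B16 cells (Mus musculus) for antiproliferative activity, read by MTT assay, with a stated time of 24 h (on this read-out lower numbers stand for stronger inhibition and higher numbers for weaker inhibition), the compounds measured so far give these values.

Compound 1 `C#CCOc1ccc2c(=O)c(-c3cc(OC)c(OC)cc3OC)coc2c1` gives 4500 nM
Compound 2 `COc1cc(OC)c(-c2coc3cc(OCc4ccccc4)ccc3c2=O)cc1OC` gives 2330 nM
Compound 3 `COc1cc(OC)c(-c2coc3cc(OCc4ccccc4F)ccc3c2=O)cc1OC` gives 1610 nM

Compound 3 shares the low end of this small set, but not alone. The nearest comparison is a 1.4-fold lower number from compound 2 to compound 3 (0.16 log units; within the scatter), and the widest is a 2.8-fold lower number from compound 1 to compound 3 (0.45 log units; beyond the scatter).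

The next molecule, compound 4 `COc1cc(OC)c(-c2coc3cc(OCc4ccc(Br)cc4)ccc3c2=O)cc1OC`, differs from compound 3 in one place: 4-bromophenyl in place of 2-fluorophenyl on a saturated chain carbon bound to an oxygen on an aromatic ring. For the measured compounds named here, no measured step involves a 4-bromophenyl group, so the evidence is indirect. Adding a fluoro group to the phenyl ring gave a 1.4-fold lower number from compound 2 to compound 3 (0.16 log units; within the scatter). Replacing ethynyl with phenyl gave a 1.9-fold lower number from compound 1 to compound 2 (0.29 log units; within the scatter). Changes to this aromatic ring have therefore moved the number little so far, although three compounds are a thin basis. No step beyond the scatter is expected in this assay, and neither direction is favoured. The estimated move is a 1.1-fold higher number from compound 3 to compound 4 (0.05 log units; within the scatter). The expected value for compound 4 is 1800 nM, with an estimated range of 800 nM to 4000 nM.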

Compound 4, half-maximal inhibitory concentration: 1180 nM
Compound 4: middle estimate off by 1.5-fold (0.18 log units), on the high side, within the range that was stated.
By their numbers in this assay, from the lowest: compounds 4, 3, 2 and 1 (each within the scatter of the next, the first and the last beyond it).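

Compound 4 shows that 4-bromophenyl can take the place of 2-fluorophenyl with little effect in this assay: the swap gives a 1.4-fold lower number from compound 3 to compound 4 (0.13 log units; within the scatter) and adding bromo to the plain phenyl ring gives a 2.0-fold lower number from compound 2 to compound 4 (0.30 log units; within the scatter) and neither step leaves the scatter. Among the compounds shown here, the only new step beyond the scatter starts from the ethynyl group, at a 3.8-fold lower number from compound 1 to compound 4 (0.58 log units; beyond the scatter) and it joins the step to compound 3 in favouring a halogen-bearing phenyl ring over ethynyl, while compound 2, with no halogen, goes against this by staying within the scatter of compound 1. Nothing measured here explains these numbers.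

The swap changes both the halogen and its place on the ring, so the two cannot be told apart. As far as these compounds go, how an amine or a carboxylic acid on this ring, or a longer chain in place of the benzyl group, would behave remains open.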